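The source may report more compounds than this note shows. Statements on the series, on what has been measured and on what is new or still open speak of the compounds shown alone.

In a functional assay on MCF7 cells (Homo sapiens) for antiproliferative activity, read by MTT assay, with a stated time of 72 h (a higher number here means a weaker inhibitor, a lower number a stronger inhibitor), compound 2 `CCN1CCN(c2cc(C)c3cc(NC(=O)c4ccc(C)cc4)ccc3n2)CC1` gives 6740 nM as the second highest of three numbers. On the same scale the highest number is that of compound 1 `CCN1CCN(c2cc(C)c3cc(NC(=O)c4ccc[nH]4)ccc3n2)CC1` at 14700 nM, and the lowest is that of compound 3 `CNc1cc(C)c2cc(NC(=O)c3ccc(Cl)c(Cl)c3)ccc2n1` at 2520 nM. Compound 4 `CCN1CCN(c2cc(C)c3cc(NC(=O)c4cccc(C)c4)ccc3n2)CC1` has the same atoms as compound 2, joined differently, with 3-methylphenyl in place of 4-methylphenyl on a carbonyl carbon. For the measured compounds named here, the only measured step at that carbonyl carbon is a 2.2-fold lower number from compound 1 to compound 2 (0.34 log units; beyond the scatter) and it was modest, exchanging 1H-pyrrol-2-yl for 4-methylphenyl. No measurement compares the two methylphenyl groups, so no step beyond the scatter is expected in this assay and no direction is favoured. The expected step is a 1.0-fold lower number from compound 2 to compound 4 (0.02 log units; within the scatter) and lies within the scatter. Compound 4 is estimated at 6500 nM with an expected range of 2800 nM to 15000 nM around it.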

Compound 4, half-maximal inhibitory concentration: 7800 nM
Estimate against measurement, compound 4: 1.2-fold (0.08 log units) below; the measured number falls inside the stated range.
By their numbers in this assay, from the lowest: compound 3; then compounds 2, 4 and 1 (each within the scatter of the next, the first and the last beyond it).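

In this assay, for the compounds shown here, the first direct comparison of the two methylphenyl groups on the carbonyl carbon shows a 1.2-fold higher number from compound 2 to compound 4 (0.06 log units; within the scatter) and so does not separate 3-methylphenyl from 4-methylphenyl. Measured against 1H-pyrrol-2-yl, 3-methylphenyl shows a 1.9-fold lower number from compound 1 to compound 4 (0.28 log units; within the scatter) and so does not hold the modest gain seen with 4-methylphenyl beyond the scatter. No evidence is available to explain these results. On these data alone, it remains open whether an amine or a carboxylic acid in place of the methyl on this phenyl ring would change the number in this assay by more than the scatter.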